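Methyl in place of chloro in compound 3

This account rests on a few compounds, and the source may have more. Where it says the series, first, only, none or still open, it means among the compounds named here.

compound 1 `CC(NC(=O)NS(=O)(=O)c1ccc(Cl)cc1)c1cc(Br)ccc1OCc1ccccc1` gives 57500 nM
compound 2 `CC(NC(=O)NS(=O)(=O)c1ccc(Cl)cc1)c1ccccc1OCc1ccccc1` gives 157000 nM

Among the measured compounds shown here, in a functional assay on thoracic aorta (Rattus norvegicus, strain Wistar), with a stated time of 15 min (on this read-out lower numbers stand for an effect already at smaller amounts and higher numbers for an effect only at larger amounts of compound), compound 2 stands at the higher of the two numbers (157000 nM) with compound 1 as its only neighbour. Compound 3 `Cc1ccc(S(=O)(=O)NC(=O)NC(C)c2ccccc2OCc2ccccc2)cc1` alters compound 2 at one place, with methyl in place of chloro on an aromatic carbon, para to a large group (methyl in place of chloro on an aromatic carbon). For the measured compounds named here, the only measured step is a 2.7-fold higher number from compound 1 to compound 2 (0.44 log units; beyond the scatter) for hydrogen in place of bromo on an aromatic carbon. Going by the values given here, that modest step is a different exchange elsewhere in the molecule, and no measured step covers chloro and methyl. No change beyond the scatter is therefore expected in this assay, and no direction can be favoured. The expected step is a 1.1-fold higher number from compound 2 to compound 3 (0.03 log units; within the scatter) and stays within the scatter. Compound 3 is estimated at 170000 nM with a range from 70000 nM to 400000 nM in this read-out.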

Compound 3, half-maximal effective concentration: > 200000 nM
Compound 3: only a limit was reported; the forecaster's own chance of this, stated with the estimate: 15%; middle value at least 1.1-fold (0.07 log units) away from the limit.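

Among the compounds shown here, compound 3 gives the first reading at the place on the aromatic ring para to a large group, whereas the earlier pair differed elsewhere in the molecule. In this assay, methyl in place of chloro gives an at least 1.2-fold higher number from compound 2 to compound 3 (0.10 log units; that floor lies within the scatter). Compound 3 has only a limit and not a number: the limit of > 200000 nM in this assay, at which 1 of the 3 values shown sits.

On these data alone, this means that the true size of the step stays unknown: methyl may stand close to chloro at this place, or much further from it, and the floor alone cannot separate the two readings. The compounds shown leave open how a methoxy group, a fluoro group or an amine at this same place would read, and whether bromo on the shared core would still shift the number when methyl replaces chloro.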